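The compounds below may be only part of what the source reports. "The series", "measured", "known", "first", "only" and "open" are said of these compounds alone.

Of the compounds shown here, two on a shared core have been tested in a functional assay, tested at 200 ug/mL; a lower number here means a stronger effect, a higher number a weaker effect of the compound at the concentration tested. Compound 1 `CCOC(=O)C1=C(C)N(c2ccccc2)C=CC1c1ccccc1` gives -29.3%, and compound 2 `COC(=O)C1=C(C)N(c2ccccc2)C=CC1c1ccccc1` gives -23%; the two numbers lie within the usual scatter of each other, so compound 2 cannot be set apart from compound 1 on this assay. Going by the values given here, the only measured step here, a number 6.3 percentage points higher from compound 1 to compound 2 (within the scatter), concerns the same part of the molecule that changes next. Compound 3 `CC1=C(C(=O)OC(C)(C)C)C(c2ccccc2)C=CN1c1ccccc1` differs from compound 2 in one place: tert-butyl in place of methyl on an oxygen next to a carbonyl group. Among the compounds with values here, the one step that bears on this change was within the scatter, so in this assay a step beyond the scatter is not expected, though the change is larger than the one measured and the estimate is given a wide range. The expected step is a number 4 percentage points lower from compound 2 to compound 3 (within the scatter). Compound 3 is therefore estimated at -27%, between -48% and -5%.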

Compound 3, a percentage reported as activity, at one concentration (the size of the read-out at that concentration, not a potency): -37.1%
The estimate for compound 3 lay 10.1 percentage points above the measured number, within the range that was stated.
By their numbers in this assay, from the lowest: compounds 3, 1 and 2 (each within the scatter of the next, the first and the last beyond it).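

Going by these compounds alone, replacing methyl with tert-butyl on an oxygen next to a carbonyl group gives the first step at this position in this assay to pass the scatter, a number 14.1 percentage points lower from compound 2 to compound 3 (beyond the scatter) and so shows that this place can affect the read-out. Replacing ethyl with tert-butyl at the same place gives a number 7.8 percentage points lower from compound 1 to compound 3 (within the scatter) and does not set the two compounds apart, so only the change from methyl to tert-butyl can be read as a real difference. Nothing measured here explains the step.

On these data alone, it stays open how an isopropyl group, a longer chain such as n-butyl or a free carboxylic acid at this place would read out. The rest of the shared core is identical in all three compounds, so they say nothing about changes elsewhere.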